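The compounds below may be only part of what the source reports. "The series", "measured", "known", "first", "only" and "open" are said of these compounds alone.

Compound 3, with the structure `Cc1ccccc1Cc1cnc(CCc2ccc(-c3ccccc3C(=O)O)cc2)[nH]1`, is measured in an in vitro functional assay on cells for agonist activity at Bombesin receptor subtype-3 (Mus musculus), read by luminescence and calcium flux (on this read-out higher numbers stand for an effect only at larger amounts of compound and lower numbers for an effect already at smaller amounts), at 9.3 nM. Among the three compounds measured so far, compound 3 holds the second highest number. Its nearest neighbour is compound 1, `O=C(O)c1ccccc1-c1ccc(CCc2ncc(CC3CCCCCC3)[nH]2)cc1`, which in this assay gives 5.7 nM; the step of a 1.6-fold higher number from compound 1 to compound 3 (0.21 log units; within the scatter) lies within the scatter. The furthest is compound 2, `O=C(O)c1ccccc1-c1ccc(CCc2ncc(Cc3ccccc3Cl)[nH]2)cc1`, which in this assay gives 22 nM; the step of a 2.4-fold lower number from compound 2 to compound 3 (0.37 log units; beyond the scatter) is modest but real.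

Compound 4, `CCC(C)(CC)Cc1cnc(CCc2ccc(-c3ccccc3C(=O)O)cc2)[nH]1`, is the next compound. The change from compound 3 to compound 4 is 1-ethyl-1-methylpropyl in place of 2-methylphenyl on a saturated chain carbon bound to an aromatic carbon.

Among the measured compounds shown here, only one measured step replaces a ring group at that place with another group of a different kind: a 1.6-fold higher number from compound 1 to compound 3 (0.21 log units; within the scatter), which exchanged cycloheptyl for 2-methylphenyl and stayed within the scatter. The step of a 3.9-fold higher number from compound 1 to compound 2 (0.59 log units; beyond the scatter) shows that a change at this place can move the number modestly. Compound 4, carrying a branched chain rather than a ring, is therefore expected to land near compound 3, with the step of a 1.3-fold higher number from compound 3 to compound 4 (0.11 log units; within the scatter) expected to stay within or only just beyond the scatter. The estimate for compound 4 is 12 nM, in the range 4 nM to 35 nM.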

Compound 4, half-maximal effective concentration: 30 nM
Estimate against measurement, compound 4: 2.5-fold (0.40 log units) below; measured number inside the range.
By their numbers in this assay, from the lowest: compounds 1 and 3 (each within the scatter of the next); then compounds 2 and 4 (each within the scatter of the next).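

Until now this place held only rings, and compound 4 shows that the branched 1-ethyl-1-methylpropyl chain still gives a response in the nanomolar range, though the chain does not hold the level of every ring: a 3.2-fold higher number from compound 3 to compound 4 (0.51 log units; beyond the scatter) and a 5.3-fold higher number from compound 1 to compound 4 (0.72 log units; beyond the scatter) are both modest but real. Set against the 2-chlorophenyl ring, however, the chain makes no clear difference, as a 1.4-fold higher number from compound 2 to compound 4 (0.13 log units; within the scatter) stays within the scatter, so having a ring at this place does not by itself settle the number. Nothing shown here gives a reason for these differences.

From the compounds shown here alone, with only one open chain in the set, it remains unknown whether a straight hexyl chain would behave like this branched one. A chain ending in an amine or a hydroxyl group at this place also remains untested in the compounds shown.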